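From Isopropyl to 3-Fluorobenzyl on a Shared Core

The source may hold more compounds than are shown below. What is called first, only, known or untested is meant among the compounds shown, and "the series" means these compounds.

Of the compounds shown here, three built on one shared core have been tested in a functional assay on a cell-free system (plasma, Oryctolagus cuniculus) for inhibition, with stated times of 5 min, 1 min and 6 min; on this read-out higher numbers stand for weaker inhibition and lower numbers for stronger inhibition. Compound 1 `CCOC(=O)c1c(C)nc(-c2ccccc2C#N)n1OC` gives 14900 nM. Compound 2 `CCOC(=O)c1c(C)nc(-c2ccc(C#N)cc2)n1OC` gives 13400 nM. Compound 3 `CCOC(=O)c1c(C)nc(-c2cccc(C#N)c2)n1OC(C)C` gives 6740 nM, the lowest number of the three; its gap to compound 2 lies within the usual scatter of repeated measurements, while its gap to compound 1 lies beyond it. Compound 4 `CCOC(=O)c1c(C)nc(-c2cccc(C#N)c2)n1OCc1cccc(F)c1` has not yet been measured. It differs from compound 3 in a single place: 3-fluorobenzyl in place of isopropyl on an oxygen on an aromatic ring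

Among the compounds with values here, no pair of measured compounds differing in one place exists here, so there is no measured guide for this particular change, and any expectation rests on the three numbers alone. The entering group brings one aromatic ring where the leaving isopropyl had none; the guess is a moderate move toward stronger inhibition, though a result close to compound 3 would not be surprising. For compound 4 the estimate in this assay is 3000 nM, with a range from 800 nM to 12000 nM. The expected change is a 2.2-fold lower number from compound 3 to compound 4 (0.35 log units; beyond the scatter), and it may well stay within the scatter.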

Compound 4, half-maximal inhibitory concentration: 22400 nM
For compound 4 the middle estimate is 7.5-fold (0.87 log units) below the measured one; measured number outside the range, above it.
By their numbers in this assay, from the lowest: compounds 3, 2, 1 and 4 (each within the scatter of the next, the first and the last beyond it).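

In this assay the change from isopropyl to 3-fluorobenzyl on an oxygen on an aromatic ring brings a 3.3-fold higher number from compound 3 to compound 4 (0.52 log units; beyond the scatter) and so means weaker inhibition. Within the data shown here, this is the first measured step at this place, and it shows that the group on this oxygen can shift the read-out by more than the usual scatter of repeated measurements. It also shows that, for this one pair, the larger group carrying an aromatic ring gave no gain, and nothing available explains the loss.

From the compounds shown here alone, this single step cannot separate the contribution of the aromatic ring from that of the fluorine, so the result for a plain benzyl group stays open. Also open, going by these compounds, is where an ethyl group or a longer chain such as n-butyl would fall relative to compound 3 and compound 4.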